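Semicarbazone aryl swap: from compound 3 to compound 4

A few compounds are considered here, and "the series" means these few. Any claim that something is new, unique, unknown or untested is made for them only; others in the source may bear on it.

Measured in a functional assay on PC-3 cells (Homo sapiens) for antiproliferative activity, read by MTT assay, with a stated time of 72 h; on this read-out lower numbers stand for stronger inhibition and higher numbers for weaker inhibition:
- compound 1 `O=C(N/N=C/c1ccccc1)Nc1ccc(Oc2ccnc3[nH]ccc23)c(F)c1`: 7940 nM
- compound 2 `O=C(N/N=C/c1ccc(Cl)c(Cl)c1)Nc1ccc(Oc2ccnc3[nH]ccc23)c(F)c1`: 14100 nM
- compound 3 `O=C(N/N=C/c1ccc(F)cc1Cl)Nc1ccc(Oc2ccnc3[nH]ccc23)c(F)c1`: 3 nM

Compound 3 holds the lowest number of the three, and the steps that reach it are large and beyond the scatter: a 2600-fold lower number from compound 1 to compound 3 (3.42 log units; beyond the scatter) and a 4700-fold lower number from compound 2 to compound 3 (3.67 log units; beyond the scatter). Compound 4 `O=C(N/N=C/c1cc(Br)c(O)c(Br)c1)Nc1ccc(Oc2ccnc3[nH]ccc23)c(F)c1` is still unmeasured and carries this change: 3,5-dibromo-4-hydroxyphenyl in place of 2-chloro-4-fluorophenyl on a carbon with a double bond to nitrogen. Within the data shown here, all the measured steps fall at this same place. The step of a 1.8-fold higher number from compound 1 to compound 2 (0.25 log units; within the scatter) lies within the scatter, so only the 2-chloro-4-fluorophenyl group has given a low number. With that group gone, a large upward step is expected in this assay, though with wide uncertainty. The expected change is a 330-fold higher number from compound 3 to compound 4 (2.52 log units; beyond the scatter). The estimate for compound 4 is 1000 nM, with an expected range of 20 nM to 15000 nM.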

Compound 4, half-maximal inhibitory concentration: "not active" (no number reported)
Compound 4: no number reported; there is nothing to compare the estimate with.
By their numbers in this assay, from the lowest: compound 3; then compounds 1 and 2 (each within the scatter of the next).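

Among these compounds, compound 4 is reported as "not active" with no number in this assay so no step from compound 3 to compound 4 can be read. The compounds shown leave open whether any other aryl group on the semicarbazone matches the low number of compound 3. No evidence bears on this result.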